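Solubility at Neutral pH for Compound 1 and Its Relatives

This account rests on a few compounds, and the source may have more. Where it says the series, first, only, none or still open, it means among the compounds named here.

Measured compounds:
compound 1 `CC(C)(C)C(=O)N1Cc2c(NC(=O)c3ccncc3)n[nH]c2C1(C)C` — 205000 nM
compound 2 `CN1CCC(C(=O)N2Cc3c(NC(=O)Nc4cccc(F)c4)n[nH]c3C2(C)C)CC1` — > 225000 nM
compound 3 `CN1CCC(C(=O)N2Cc3c(NC(=O)c4ccc(Cl)cc4)n[nH]c3C2(C)C)CC1` — > 225000 nM

Of the compounds shown here, three have been measured in a physicochemical assay for solubility, at pH 7; a higher number here means a more soluble compound, a lower number a less soluble compound. Compound 1 is the only one of them with an actual number, giving 205000 nM in this assay. For compound 2 the assay reports only a limit, > 225000 nM. For compound 3 the assay likewise reports only a limit, > 225000 nM. Among the measured compounds shown here, the single step between measured compounds that differ in one place, a step that the two limits leave unreadable from compound 2 to compound 3, therefore cannot be read, since both of its ends rest at the limit of > 225000 nM in this assay, at which 2 of the 3 values shown sit.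

Compound 4 `CN(C)CC(=O)Nc1n[nH]c2c1CN(C(=O)C(C)(C)C)C2(C)C` differs from compound 1 in one place: (dimethylamino)methyl in place of pyridin-4-yl on a carbonyl carbon. For the measured compounds named here, no measured step carries this same change, so the expectation has to rest on where compound 1 already stands, which is close to the limit at which the other two compounds sit (the limit of > 225000 nM in this assay, at which 2 of the 3 values shown sit). A modest upward step is expected, a 1.2-fold higher number from compound 1 to compound 4 (0.09 log units; within the scatter), and it seems more likely than not that the assay will again return only a limit rather than a number for compound 4. The estimate for compound 4 is 250000 nM, with a range from 150000 nM to 500000 nM.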

Compound 4, solubility: > 225000 nM
Compound 4 ended at the assay's limit; the forecaster's own chance of this, stated with the estimate: 65%; the middle value lies beyond the limit too.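

In this assay compound 4 gives only a limit, > 225000 nM. The replacement of pyridin-4-yl by (dimethylamino)methyl on a carbonyl carbon gives an at least 1.0-fold higher number from compound 1 to compound 4 (0.04 log units; that floor lies within the scatter), so this change has a floor but no readable size. What compound 4 adds is that a group with no ring can stand at this place on the core of compound 1 while the read-out still reaches the limit of the assay, something that compound 1, with its six-membered aromatic ring here, could not show on its own: the limit of > 225000 nM in this assay, at which 3 of the 4 values shown sit.

With so many values resting at that limit, neither the true size of this change nor the step between compound 2 and compound 3 can be read. From the compounds shown here alone, it remains open whether a carboxylic acid, a morpholine or a longer chain in place of (dimethylamino)methyl on the same carbonyl carbon would return a number or again only a limit in this assay.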